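A few compounds are considered here, and "the series" means these few. Any claim that something is new, unique, unknown or untested is made for them only; others in the source may bear on it.

Compound 1 `Clc1ccc2[nH]c(SCc3ccccc3Oc3ccccc3)nc2c1` was examined in an assay on isolated protein for inhibition of Indoleamine 2,3-dioxygenase 1 (Homo sapiens), with a stated time of 60 min, tested at 10 uM (a higher number here means more inhibition at the concentration tested (going by the name of the read-out), a lower number less inhibition), where compound 1 gives 30%. Compound 2 `Clc1ccc2oc(SCc3ccccc3CCc3ccccc3)nc2c1` gives 21% in this assay, a number within the scatter of that of compound 1, so neither stands apart from the other. Compound 3 `Clc1ccc2[nH]c(SCc3ccccc3/C=C/c3ccccc3)nc2c1` has not yet been measured. It differs from compound 1 by 2-phenylethenyl in place of phenoxy on an aromatic carbon. The step is expected to be small, a number 2 percentage points lower from compound 1 to compound 3 (within the scatter), and not beyond the scatter, because compound 1 gives only 30% and compound 2 gives 21% in this assay. Compound 3 is estimated to give 28%, within 10% to 50%.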

Compound 3, a percentage reported as inhibition, at one concentration (the size of the read-out at that concentration, not a potency): -6%
Compound 3: the middle estimate sits 34 percentage points above what was measured; measured number below the stated range.
By their numbers in this assay, from the lowest: compound 3; then compounds 2 and 1 (each within the scatter of the next).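

In this assay, 2-phenylethenyl in place of phenoxy on this aromatic carbon, ortho to a large group, gives a number 36 percentage points lower from compound 1 to compound 3 (beyond the scatter) and so shows that the position does not treat these two groups alike. Both carry one six-membered aromatic ring of carbon only, so that ring alone does not preserve the inhibition seen with phenoxy. Nothing available explains the size of this step.

From the compounds shown here alone, whether the oxygen or the double bond matters more remains open. So does how a smaller methoxy group or an amine would behave at this position.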